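Trimming the aryl substituent down to a methyl group

The source may hold more compounds than are shown below. What is called first, only, known or untested is meant among the compounds shown, and "the series" means these compounds.

Measured compounds:
compound 1, `Cc1nc2c3ccccc3ccc2c2nc3c(ccc4ccccc43)c(-c3nccnc3N)c12`: 3560 nM
compound 2, `Cc1nc2c3ccccc3ccc2c2nc3c(ccc4ccccc43)c(-c3ccc(O)cc3)c12`: 3190 nM

In a functional assay on HCT-116 cells (Homo sapiens) for cytotoxicity, read by MTT assay, with a stated time of 48 h (on this read-out higher numbers stand for weaker inhibition and lower numbers for stronger inhibition), compound 2 gives 3190 nM, and compound 1 gives 3560 nM; the step of a 1.1-fold lower number from compound 1 to compound 2 (0.05 log units; within the scatter) lies within the scatter, so neither compound can be ranked above the other. Compound 3, `Cc1nc2c3ccccc3ccc2c2nc3c(ccc4ccccc43)c(C)c12`, carries the change (methyl in place of 4-hydroxyphenyl on an aromatic carbon). Within the data shown here, no measured step exchanges an aromatic ring for a single carbon, so the only comparison, compound 1 to compound 2, does not bear on it directly. In this assay compound 3 is therefore expected near 5000 nM, between 1600 nM and 16000 nM, a step of a 1.6-fold higher number from compound 2 to compound 3 (0.20 log units; within the scatter) that is uncertain in either direction.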

Compound 3, half-maximal inhibitory concentration: > 80000 nM
Compound 3: only a limit was reported (the forecaster's own chance of this, stated with the estimate: 10%); middle value at least 16-fold (1.20 log units) from the limit.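

At this aromatic carbon, opposite the ring nitrogen, the two aromatic substituents could not be told apart, but methyl separates clearly from both, with an at least 25-fold higher number from compound 2 to compound 3 (1.39 log units; beyond the scatter) and an at least 22-fold higher number from compound 1 to compound 3 (1.35 log units; beyond the scatter). Among these compounds, a ring at this position therefore goes with measurable cytotoxicity, and its loss with none detected up to the limit. Compound 3 gives only a limit in this assay: the limit of > 80000 nM in this assay, at which 1 of the 3 values shown sits.

Going by these compounds, whether aromaticity or simply size matters stays open, since a cyclohexyl ring or a longer chain such as butyl could separate the two. How far compound 3 lies past its limit cannot be told.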